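Exchanging the Aryl on the Carbonyl: Compound 3 to Compound 4

The source may report more compounds than this note shows. Statements on the series, on what has been measured and on what is new or still open speak of the compounds shown alone.

Of the compounds shown here, three sharing one core have been measured in a functional assay on A549 cells (Homo sapiens) for cytotoxicity, read by sulforhodamine B assay, with a stated time of 48 h, tested at 100 uM; a lower number here means a stronger effect, a higher number a weaker effect of the compound at the concentration tested. Compound 1 `COc1cc(-c2cc(/C=C/C(=O)c3ccc(N)cc3)[nH]n2)cc(OC)c1OC` gives -52%. Compound 2 `COc1cc(-c2cc(/C=C/C(=O)c3ccc(Cl)c(Cl)c3)[nH]n2)cc(OC)c1OC` gives 2%, and compound 3 `COc1ccc(C(=O)/C=C/c2cc(-c3cc(OC)c(OC)c(OC)c3)n[nH]2)cc1` gives 1%. Among these three numbers compound 3 stands second highest; its nearest neighbour is compound 2, whose value lies within the scatter of it, while the furthest is compound 1, as the step of a number 53 percentage points higher from compound 1 to compound 3 (beyond the scatter) shows. The step of a number 54 percentage points higher from compound 1 to compound 2 (beyond the scatter) is of the same kind. By contrast, the step of a number 1 percentage points lower from compound 2 to compound 3 (within the scatter) stays within the scatter.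

Compound 4 `COc1cc(-c2cc(/C=C/C(=O)c3ccc(F)c(F)c3)[nH]n2)cc(OC)c1OC` differs from compound 3 in one place: 3,4-difluorophenyl in place of 4-methoxyphenyl on a carbonyl carbon. Among the measured compounds shown here, the one measured step that bears on this change is the one in which 4-methoxyphenyl replaced 3,4-dichlorophenyl on the carbonyl carbon, a number 1 percentage points lower from compound 2 to compound 3 (within the scatter), and it was within the scatter. Since compound 2, carrying 3,4-dichlorophenyl, gives 2% and compound 3 gives 1%, no movement beyond the scatter is expected when 3,4-difluorophenyl takes the same place. The expected step is a number 1 percentage points higher from compound 3 to compound 4 (within the scatter), within the scatter. Compound 4 is therefore estimated at 2%, with a range from -12% to 15%.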

Compound 4, a percentage reported as activity, at one concentration (the size of the read-out at that concentration, not a potency): -15%
The estimate for compound 4 lay 17 percentage points above the measured number; measured number below the stated range.
By their numbers in this assay, from the lowest: compound 1; then compound 4; then compounds 3 and 2 (each within the scatter of the next).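

At this position the aryl group can move the read-out in this assay even without an amino group: there is a number 16 percentage points lower from compound 3 to compound 4 (beyond the scatter) and also a number 17 percentage points lower from compound 2 to compound 4 (beyond the scatter), although the exchange between 3,4-dichlorophenyl and 4-methoxyphenyl had stayed within the scatter. The change from 3,4-dichlorophenyl to 3,4-difluorophenyl therefore matters here, and two aryl groups with the same pattern of substitution need not behave alike on this carbonyl carbon. The gain from 3,4-difluorophenyl still stops short of 4-aminophenyl, as a number 37 percentage points higher from compound 1 to compound 4 (beyond the scatter) shows, so compound 1 keeps the lowest number of the four. Nothing available explains why these groups differ in this way.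

The compounds shown leave open whether a single fluorine on the phenyl ring, or a bromine or trifluoromethyl group in place of the two halogens, would follow the 3,4-difluorophenyl or the 3,4-dichlorophenyl result. They also leave open whether an acetamide or a dimethylamino group on that ring would keep the large effect seen with the amino group of compound 1.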